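Cytotoxicity notes: phenylsulfonylamino variant of compound 1

The source may hold more compounds than are shown below. What is called first, only, known or untested is meant among the compounds shown, and "the series" means these compounds.

Measured so far:
- compound 1 `O=C1Nc2ccc(S(=O)(=O)N3CCOCC3)cc2/C1=N/c1ccc(O)cc1`: 259000 nM
- compound 2 `COc1ccc(-c2c(C#N)c(N)n(/N=C3\C(=O)Nc4ccc(S(=O)(=O)N5CCOCC5)cc43)c(=O)c2C#N)cc1`: 224000 nM

In an ADME assay on WI-38 cells (Homo sapiens) for cytotoxicity, read by sulforhodamine B assay, with a stated time of 24 h (a lower number here means a stronger inhibitor, a higher number a weaker inhibitor), compound 1 gives 259000 nM. Compound 2, which carries the same core inside a larger substituted arrangement, gives 224000 nM. The two numbers lie within the scatter of each other, so neither compound can be told apart from the other on these data; both sit at weak inhibition.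

Compound 3 `O=C1Nc2ccc(S(=O)(=O)N3CCOCC3)cc2/C1=N/NS(=O)(=O)c1ccccc1` is not yet measured. Compared with compound 1 the change is (phenylsulfonyl)amino in place of 4-hydroxyphenyl on a double-bonded nitrogen. Going by the values given here, no pair of measured compounds spans this change, so there is no measured step to lean on. Given that compound 1 and compound 2 both read weak, the expectation for compound 3 is a step of a 1.2-fold lower number from compound 1 to compound 3 (0.07 log units; within the scatter), that is, none beyond the scatter in either direction. Compound 3 is estimated at 220000 nM, with a range from 80000 nM to 600000 nM.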

Compound 3, half-maximal inhibitory concentration: 302000 nM
The estimate for compound 3 lay 1.4-fold (0.14 log units) below the measured number; measured number inside the range.
By their numbers in this assay, from the lowest: compounds 2, 1 and 3 (each within the scatter of the next).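

In this assay the change to (phenylsulfonyl)amino in place of 4-hydroxyphenyl on a double-bonded nitrogen gives a 1.2-fold higher number from compound 1 to compound 3 (0.07 log units; within the scatter) and stays within the scatter. Going by these compounds alone, this is the first single-place step, and it shows that this place takes a group with more heavy atoms, a sulfur and one more hydrogen-bond acceptor without a step beyond the scatter. Nothing available bears on the reason for this result.

From the compounds shown here alone, both groups compared here carry a six-membered aromatic ring of carbon only, so the reading for a group without that ring remains open. Going by these compounds, whether an amine, a carboxylic acid or a longer alkyl chain on this double-bonded nitrogen would move the number beyond the scatter also remains open.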